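The source may report more compounds than this note shows. Statements on the series, on what has been measured and on what is new or still open speak of the compounds shown alone.

Measured compounds:
compound 1 `NS(=O)(=O)Oc1ccc2c(c1)CN(C(=O)c1cccc(N(Cc3ccccc3)Cc3ccco3)c1)CC2` with 90.5%
compound 2 `CN(C)CCN(CCN(C)C)c1cccc(C(=O)N2CCc3ccc(OS(N)(=O)=O)cc3C2)c1` with 17.1%

In an assay on HEK293 cells for inhibition of Steryl-sulfatase (Homo sapiens), tested at 1 uM (on this read-out lower numbers stand for a weaker effect and higher numbers for a stronger effect at the one concentration tested), compound 1 gives 90.5%, while compound 2 gives 17.1%, the lowest of the two numbers and a gap that lies beyond the scatter. The step under study leads from compound 2 to compound 3 `CCCN(Cc1ccccc1)c1cccc(C(=O)N2CCc3ccc(OS(N)(=O)=O)cc3C2)c1`, which has not yet been tested in this assay. The structural change is benzyl(propyl)amino in place of bis(2-(dimethylamino)ethyl)amino on an aromatic carbon. Within the data shown here, since no step between measured compounds is available here, the expectation rests on the two values alone: compound 3 is closer in make-up to compound 1 than compound 2 is, and compound 1 gives 90.5%. A large rise is therefore expected, with a number 60.9 percentage points higher from compound 2 to compound 3 (beyond the scatter) as the estimated step. For compound 3 the estimate in this assay is 78%, expected to fall between 55% and 95%.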

Compound 3, a percentage reported as inhibition, at one concentration (the size of the read-out at that concentration, not a potency): 67.4%
Beside the measured number, compound 3's estimate is 10.6 percentage points above it; the measured number falls inside the stated range.
By their numbers in this assay, from the lowest: compound 2; then compound 3; then compound 1.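

On this aromatic carbon, in this assay, benzyl(propyl)amino in place of bis(2-(dimethylamino)ethyl)amino gives a number 50.3 percentage points higher from compound 2 to compound 3 (beyond the scatter), so the position responds strongly to the change between these two groups of equal heavy-atom count. Compound 1 adds a second reading at the same position: ethyl in place of furan-2-yl on the saturated chain carbon gives a number 23.1 percentage points lower from compound 1 to compound 3 (beyond the scatter), a modest step that is smaller than the first. Nothing measured here accounts for either step.

The compounds shown leave open whether the large step follows the loss of the dimethylamino groups or the arrival of the benzyl ring, which a single 2-(dimethylamino)ethyl chain alongside benzyl could separate. They also leave open how a thiophen-2-yl group would compare with furan-2-yl and ethyl on that chain carbon.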